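The source may report more compounds than this note shows. Statements on the series, on what has been measured and on what is new or still open speak of the compounds shown alone.

Measured so far in a functional assay on K562 cells (Homo sapiens) for inhibition, read by trypan blue exclusion, with a stated time of 72 h; on this read-out lower numbers stand for stronger inhibition and higher numbers for weaker inhibition:
compound 1 `Cn1c(=O)c(S(=O)(=O)c2ccc(F)cc2F)cc2cnc(Nc3ccc4[nH]c(C(=O)O)cc4c3)nc21` — 10000 nM
compound 2 `Cn1c(=O)c(S(=O)(=O)c2ccc(C(=O)O)cc2)cc2cnc(Nc3ccc4[nH]ccc4c3)nc21` — 5000 nM
compound 3 `O=c1c(S(=O)(=O)c2ccc(F)cc2F)cc2cnc(Nc3ccc4[nH]ccc4c3)nc2n1C1CCCC1` — 5000 nM

Compound 1 shows the highest number of the three, yet its gaps to compound 2 and to compound 3 both lie within the usual scatter, so the three read as one loose cluster and none can be set apart.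

Compound 4 `Cn1c(=O)c(S(=O)(=O)c2ccc(F)cc2F)cc2cnc(Nc3ccc4cc[nH]c4c3)nc21` is not yet measured. Against compound 1 it carries one change: 1H-indol-6-yl in place of 2-carboxy-1H-indol-5-yl on a nitrogen on an aromatic ring. No measured pair in this set separates this change from others, so the step from compound 1 to compound 4 has no direct precedent; the cluster of values gives no reason to expect a move beyond the scatter in either direction. The step is expected at a 1.7-fold lower number from compound 1 to compound 4 (0.22 log units; within the scatter). Compound 4 is estimated at 6000 nM, with a range from 1500 nM to 20000 nM in this assay.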

Compound 4, half-maximal inhibitory concentration: 5000 nM
Compound 4: the middle estimate sits 1.2-fold (0.08 log units) above what was measured; measured number inside the range.
By their numbers in this assay, from the lowest: compounds 2, 3, 4 and 1 (each within the scatter of the next).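

In this assay, among the compounds shown here, 1H-indol-6-yl in place of 2-carboxy-1H-indol-5-yl on a nitrogen on an aromatic ring gives a 2.0-fold lower number from compound 1 to compound 4 (0.30 log units; within the scatter), the first single-place step. At this place, the carboxylic acid and the original attachment can therefore both go without a move beyond the scatter. For the compounds shown here, no evidence on the compounds bears on this result.

The step carries both differences together, so the share of each stays unresolved. Also open, going by these compounds, is whether a morpholine or a dimethylamino group at this place would give a number beyond the scatter.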